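Methyl for Fluoro on the Aryl Ring of Compound 2

The source may hold more compounds than are shown below. What is called first, only, known or untested is meant among the compounds shown, and "the series" means these compounds.

Measured so far:
compound 1, `Cc1ccc([C@@H]2CN(C)[C@]3(C(=O)Nc4ccccc43)[C@]23Cc2ccccc2C3=O)cc1`, 23.8%
compound 2, `CN1C(=O)[C@@]2(c3ccccc31)N(C)C[C@@H](c1ccc(F)cc1)[C@@]21Cc2ccccc2C1=O`, 24.6%

Compound 1 and compound 2 were both tested in a functional assay on the whole organism (strain Wister albino) for inhibition, with Rattus norvegicus as the target, read by paw edema, with stated times of 1 h and 2 h, at a dose of 50 mg/kg by the intraperitoneal route; a higher number here means more inhibition at the dose given (going by the name of the read-out), a lower number less inhibition. In this assay compound 1 gives 23.8%, and compound 2 gives 24.6%. The two numbers lie within the scatter of each other, so compound 2 cannot be set apart from compound 1 on the numbers shown; the two compounds differ in more than one place, and no single step between them is known.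

Compound 3, `Cc1ccc([C@@H]2CN(C)[C@]3(C(=O)N(C)c4ccccc43)[C@]23Cc2ccccc2C3=O)cc1`, has not yet been measured. It differs from compound 2 in one place: methyl in place of fluoro on an aromatic carbon. Among the measured compounds shown here, the two measured compounds give no step that isolates this change, and the two values at hand sit close together. The step from compound 2 to compound 3 is therefore expected to be small, with no direction beyond the scatter: a number 0.6 percentage points lower from compound 2 to compound 3 (within the scatter). Compound 3 is estimated at 24%, within a range of 15% to 33%.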

Compound 3, a percentage reported as inhibition, in the whole organism at one dose (the size of the read-out at that dose, not a potency): 8%
For compound 3 the middle estimate is 16 percentage points above the measured one; the measured number lies below the stated range.
By their numbers in this assay, from the lowest: compound 3; then compounds 1 and 2 (each within the scatter of the next).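

In this assay, swapping the 4-fluorophenyl for 4-methylphenyl is not a neutral change when the amide-type nitrogen in the ring carries methyl: a number 16.6 percentage points lower from compound 2 to compound 3 (beyond the scatter). That nitrogen is equally sensitive when the aryl group is 4-methylphenyl, as methyl in place of hydrogen there gives a number 15.8 percentage points lower from compound 1 to compound 3 (beyond the scatter), so compound 3, the only one of the three with both methyl groups, stands apart, and each single step from it leads to a compound with a clearly higher number. Nothing at hand explains these drops.

The compounds shown leave open whether the low number needs both methyl groups together or would also appear with 4-fluorophenyl and the amide hydrogen. They also leave open how a chloro or methoxy group on that aromatic carbon, or an ethyl group on the nitrogen, would behave.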